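The compounds below may be only part of what the source reports. "The series", "measured", "known", "first", "only" and "open" are said of these compounds alone.

Measured so far:
compound 1, `CCOC(=O)C(=O)CC(=O)/C=C/c1cn(-c2ccc(Cl)cc2)c2ccccc12`; in an assay on isolated protein for inhibition of DNA nucleotidylexotransferase (Homo sapiens), read by scintillation counting, with a stated time of 10 min (a higher number here means a weaker inhibitor, a lower number a stronger inhibitor), compound 1 gives > 40 uM, a limit of the assay rather than a number.
compound 2, `CCOC(=O)C(=O)CC(=O)/C=C/c1cn(Cc2ccccc2)c2ccccc12`; in this assay compound 2 gives > 40 uM, again a limit and not a number.
compound 3, `O=C(/C=C/c1cn(-c2ccc(Cl)cc2)c2ccccc12)CC(=O)C(=O)O`; in this assay compound 3 gives 31 uM, the only number in the set.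

From compound 1 to compound 2 the change is benzyl in place of 4-chlorophenyl on an aromatic nitrogen. The step is a step that the two limits leave unreadable from compound 1 to compound 2 because of the limit of > 40 uM in this assay, at which 2 of the 3 values shown sit. From compound 1 to compound 3 the change is hydrogen in place of ethyl on an oxygen next to a carbonyl group, and the step is an at least 1.2-fold lower number from compound 1 to compound 3 (0.11 log units; that floor lies within the scatter).

Compound 4, `O=C(/C=C/c1cn(Cc2ccccc2)c2ccccc12)CC(=O)C(=O)O`, is still to be measured. It differs from compound 3 by benzyl in place of 4-chlorophenyl on an aromatic nitrogen. This is the same change as that from compound 1 to compound 2, made twice in all, and the place is described in the same words both times.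

For compound 4 the step of a 1.3-fold higher number from compound 3 to compound 4 (0.11 log units; within the scatter) is expected to be small, resting on compound 3 giving 31 uM while the earlier step is a step that the two limits leave unreadable from compound 1 to compound 2 and so gives no direction. Compound 4 is estimated at 40 uM, between 15 uM and 100 uM, with a fair chance that only a limit is reported.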

Compound 4, concentration for 50% inhibition: 7.9 uM
For compound 4 the middle estimate is 5.1-fold (0.70 log units) above the measured one; measured number outside the range, below it.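

With benzyl in place of 4-chlorophenyl on the aromatic nitrogen, this assay gives a 3.9-fold lower number from compound 3 to compound 4 (0.59 log units; beyond the scatter), while the same change between compound 1 and compound 2 cannot be read, as both ends of that step are limits of the assay, so nothing can be said about whether this change carries from one core to the other. Hydrogen in place of ethyl on an oxygen next to a carbonyl group gives an at least 5.0-fold lower number from compound 2 to compound 4 (0.70 log units; beyond the scatter), and this step can be set beside its earlier instance: the same change on two cores in this assay, an at least 1.2-fold lower number (0.11 log units; that floor lies within the scatter) from compound 1 to compound 3 and an at least 5.0-fold lower number (0.70 log units; beyond the scatter) from compound 2 to compound 4; the limit leaves it open whether they differ. This shows a step beyond the scatter for that change on the benzyl core, but it does not show that the size carries to the 4-chlorophenyl core, nor that the two sizes differ.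

Other groups on the aromatic nitrogen remain open, such as 4-chlorobenzyl or a longer chain ending in an amine. Also open, as far as these compounds go, is how an amide in place of the carboxylic acid would read in this assay.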